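The source may report more compounds than this note shows. Statements on the series, on what has been measured and on what is new or still open speak of the compounds shown alone.

In a functional assay on COLO 205 cells (Homo sapiens) for inhibition, read by sulforhodamine B assay, tested at 100 uM (on this read-out higher numbers stand for more inhibition of growth at the one concentration tested and lower numbers for less inhibition of growth), the three measured compounds spread widely. Compound 1 `CC(=O)N1N=C(c2ccc(OCc3cn(Cc4ccc([N+](=O)[O-])cc4)nn3)cc2)CC1c1ccccc1` gives 55%, compound 2 `COc1cc(C2CC(c3ccc([N+](=O)[O-])cc3)=NN2C(C)=O)ccc1OCc1cn(Cc2ccc([N+](=O)[O-])cc2)nn1` gives 85%, and compound 3 `COc1cc(C2CC(c3ccccc3)=NN2C(C)=O)ccc1OCc1cn(Cc2ccc([N+](=O)[O-])cc2)nn1` gives 11%. Among the compounds with values here, the one step that can be read across a single change is a number 74 percentage points lower from compound 2 to compound 3 (beyond the scatter), a large fall. Compound 3 thus stands lowest of the three; compound 1 sits well above it, and compound 2 furthest above.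

Compound 4 `COc1ccc(C2=NN(C(C)=O)C(c3ccc(OCc4cn(Cc5ccc([N+](=O)[O-])cc5)nn4)c(OC)c3)C2)cc1` differs from compound 3 by methoxy in place of hydrogen on an aromatic carbon. Within the data shown here, no measured step covers this change. Among the measured compounds shown here, the only measured step concerns the nitro group, where a number 74 percentage points lower from compound 2 to compound 3 (beyond the scatter) marks a large effect, and it says nothing about a methoxy entering. Compound 1 and compound 3 also differ from each other, but not by this change, so their two values give no direct guide either. With nothing in this assay speaking for or against the methoxy, a step of at most modest size is expected from compound 3 to compound 4, without a clear direction, and a number 9 percentage points higher from compound 3 to compound 4 (within the scatter) is the expectation drawn from that. Compound 4 is therefore estimated at 20%, within 0% to 45%.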

Compound 4, percent growth inhibition at one concentration: 75%
The estimate for compound 4 lay 55 percentage points below the measured number, and the stated range ends below it.
By their numbers in this assay, from the lowest: compound 3; then compound 1; then compounds 4 and 2 (each within the scatter of the next).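

In this assay, the ring that carries only hydrogen in compound 3 now proves sensitive to a second group, not only to nitro: the change from phenyl to 4-methoxyphenyl, with the methoxy para to a large group, gives a number 64 percentage points higher from compound 3 to compound 4 (beyond the scatter) and so nearly undoes the loss seen when nitro was removed. Within the data shown here, exchanging one substituent for the other at this same place gives a number 10 percentage points lower from compound 2 to compound 4 (within the scatter), so the data do not separate methoxy from nitro here, while each stands well clear of hydrogen, something the earlier compounds could show for nitro alone. No measured evidence bears on why this position responds as it does.

Going by these compounds, whether an amine, a carboxylic acid or a chloro group at this place would give a number close to those of compound 2 and compound 4, or one close to compound 3 at 11%, remains open. On these data alone, it is equally open whether a longer chain such as ethoxy would keep the gain seen with methoxy, and whether either group would act the same way elsewhere on this ring.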